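From piperidin-1-yl to pyrrolidin-1-yl on a thiocarbonyl carbon

The compounds below may be only part of what the source reports. "The series", "measured", "known", "first", "only" and "open" are said of these compounds alone.

Of the compounds shown here, two sharing one core have been tested in a functional assay on MDA-MB-231 cells (Homo sapiens) for inhibition, read by MTT assay, with stated times of 18 h and 4 h; a higher number here means a weaker inhibitor, a lower number a stronger inhibitor. Compound 1 `CCCCCCCCCCCCCCCCOP(=O)(O)OCCSC(=S)N1CCN(C)CC1` returns only a limit, > 100000 nM. Within the data shown here, compound 2 `CCCCCCCCCCCCCCCCOP(=O)(O)OCCSC(=S)N1CCCCC1` gives 100000 nM, the only actual number so far, so it has no measured neighbour to be ranked against.

Compound 3 `CCCCCCCCCCCCCCCCOP(=O)(O)OCCSC(=S)N1CCCC1` has not yet been measured. It carries pyrrolidin-1-yl in place of piperidin-1-yl on a thiocarbonyl carbon, (pyrrolidin-1-yl in place of piperidin-1-yl on a thiocarbonyl carbon). Among the measured compounds shown here, one measured step bears on this change, made at the same place: a number no higher from compound 1 to compound 2 (the limit leaves the size open). Its size cannot be read, so it offers no scale for a ring change of this kind. The expectation therefore rests on compound 2 at 100000 nM, and no shift beyond the scatter in this assay is foreseen. The estimated change is a 1.1-fold lower number from compound 2 to compound 3 (0.05 log units; within the scatter). Compound 3 is expected near 90000 nM, within an estimated range of 35000 nM to 150000 nM.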

Compound 3, half-maximal inhibitory concentration: 69000 nM
Compound 3: the middle estimate sits 1.3-fold (0.12 log units) above what was measured; measured number inside the range.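

Among these compounds, the ring change on the thiocarbonyl carbon gives the first step between two actual numbers in this assay: a 1.4-fold lower number from compound 2 to compound 3 (0.16 log units; within the scatter). At this position, then, the pyrrolidin-1-yl and piperidin-1-yl groups cannot be told apart in this read-out. Set against the 4-methylpiperazin-1-yl group, the change reads an at least 1.4-fold lower number from compound 1 to compound 3 (0.16 log units; that floor lies within the scatter), a floor and not a full size, and compound 1 rests on a limit and not on a number: the limit of > 100000 nM in this assay, at which 1 of the 3 values shown sits.

The compounds shown leave open whether any group on this carbon, such as a morpholine ring or an open-chain diethylamine, would give a step beyond the scatter. They also leave open what a shorter chain on the shared core would do to these numbers.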